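The compounds below may be only part of what the source reports. "The series", "measured", "known", "first", "only" and "open" are said of these compounds alone.

Measured so far:
compound 1 `Nc1nc(Cl)c2ncn(Cc3ccccc3CCl)c2n1`: 17800 nM
compound 2 `ClCc1cccc(Cn2cnc3nc(Cl)nc(Cl)c32)c1`: 16600 nM

In a functional assay on TK-10 cells (Homo sapiens) for cytotoxicity, read by sulforhodamine B assay, with a stated time of 48 h (a higher number here means a weaker inhibitor of growth, a lower number a stronger inhibitor of growth), compound 1 gives 17800 nM, and compound 2 gives 16600 nM. The two numbers lie within the scatter of each other, so on the numbers shown compound 1 cannot be set apart from compound 2. Among the measured compounds shown here, no single-change step between measured compounds is available, and compound 2 differs from compound 1 in more than one place, so its value shows only that a dichloro core with a chloromethylbenzyl group sits in the same range as compound 1.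

Compound 3 `ClCc1ccccc1Cn1cnc2c(Cl)nc(Cl)nc21` has not yet been measured in this assay. It differs from compound 1 as follows: chloro in place of amino on an aromatic carbon.

For the measured compounds named here, with no step of this kind on record, a step from compound 1 to compound 3 that stays within the scatter is expected, a 1.2-fold lower number from compound 1 to compound 3 (0.07 log units; within the scatter). For compound 3 the value in this assay is estimated at 15000 nM, with a range from 6000 nM to 40000 nM.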

Compound 3, concentration for 50% growth inhibition: 1450 nM
The estimate for compound 3 lay 10-fold (1.01 log units) above the measured number; the whole stated range lies above it.
By their numbers in this assay, from the lowest: compound 3; then compounds 2 and 1 (each within the scatter of the next).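

In this assay, chloro in place of amino on an aromatic carbon, between two ring nitrogen atoms, goes with a 12-fold lower number from compound 1 to compound 3 (1.09 log units; beyond the scatter). Among the compounds shown here, this is the only single-change step, and it shows that this position is sensitive to its substituent: exchanging one heavy atom for another, with the loss of the hydrogen-bond donor and acceptor counted for amino, is enough for a large step. No measurement shown bears on what lies behind this step.

With only amino and chloro at this position, the compounds shown cannot separate a gain from chloro from a loss from amino. Methoxy, methyl, bromo or dimethylamino at this position would test how far the step depends on chloro itself.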